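Selenocyanate-bearing quinazoline series: amide-to-ether linker change

A few compounds are considered here, and "the series" means these few. Any claim that something is new, unique, unknown or untested is made for them only; others in the source may bear on it.

Measured so far:
compound 1, `COc1ccc(N(C)c2nc(C)nc3ccccc23)cc1C(=O)NCC[Se]C#N`, 1250 nM
compound 2, `Cc1nc(N(C)c2ccc(OCC[Se]C#N)cc2)c2ccccc2n1`, 317 nM

In a functional assay on MDA-MB-231 cells (Homo sapiens) for inhibition, read by MTT assay, with a stated time of 48 h (a lower number here means a stronger inhibitor, a higher number a weaker inhibitor), compound 1 gives the higher of the two numbers measured. Going by the values given here, compound 2, which carries its selenocyanate on an ether chain rather than on an amide, gives a number lower by a margin that lies beyond the usual scatter; as the two compounds differ in more than one place, no single step can be drawn between them, and the pair shows only that the ether-linked compound sits at the lower value.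

Compound 3, `COc1ccc(N(C)c2nc(C)nc3ccccc23)cc1OCCCCC[Se]C#N`, is not yet measured. It keeps the core of compound 1 and differs in one place: a group of 9 heavy atoms (6 carbon, 1 nitrogen, 1 oxygen, 1 selenium; no ring) in place of a group of 8 heavy atoms (4 carbon, 2 nitrogen, 1 oxygen, 1 selenium; no ring), on an aromatic carbon The group that leaves carries the amide, the group that enters is an ether chain.

Among the compounds with values here, no step between measured compounds covers this change. Given that compound 2, with an ether-linked selenocyanate, gives 317 nM, a lowering of moderate size is expected from compound 1 to compound 3, a 2.3-fold lower number from compound 1 to compound 3 (0.36 log units; beyond the scatter), though the longer chain leaves the size uncertain. Compound 3 is estimated at 550 nM, with a range from 180 nM to 1700 nM.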

Compound 3, half-maximal inhibitory concentration: 4410 nM
Compound 3: middle estimate off by 8.0-fold (0.90 log units), on the low side, outside the stated range (above it).
By their numbers in this assay, from the lowest: compound 2; then compound 1; then compound 3.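

In this assay the aromatic carbon ortho to a methoxy group now has its first single-place reading: a 3.5-fold higher number from compound 1 to compound 3 (0.55 log units; beyond the scatter) comes with the ether chain in place of the amide-bearing group. At this position, then, an ether chain does not by itself bring a lower number, so the ether link alone cannot be taken as favourable across the series. No available measurement bears on the reason for this rise.

The compounds shown leave open whether the rise goes with the loss of the amide or with the longer chain, since both change in this one step. Also open, going by these compounds, is how a shorter ether chain at this same position would read, and whether a thiocyanate end in place of the selenocyanate would shift the number.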